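Swapping a Pyridine for a Phenyl Ring

A few compounds are considered here, and "the series" means these few. Any claim that something is new, unique, unknown or untested is made for them only; others in the source may bear on it.

Measured compounds:
- Compound 1, `CN1C(=O)C2=C(C1=O)N(CC(=O)Nc1ccc(-c3ccncc3)cc1)CCC2`: 31 mL.min-1.g-1
- Compound 2, `CN1C(=O)C2=C(C1=O)N(CC(=O)Nc1ccc(-c3cccnc3)nn1)CCC2`: 7 mL.min-1.g-1
- Compound 3, `Cc1ccc(-c2ccc(NC(=O)CN3CCCC4=C3C(=O)N(C3CC3)C4=O)nn2)cn1`: 23 mL.min-1.g-1

Of the compounds shown here, three sharing one core have been tested in an ADME assay on microsomes from liver (Homo sapiens) for metabolic stability; on this read-out higher numbers stand for fast clearance and lower numbers for slow clearance. Compound 1 gives the highest of the three numbers. Its gap to compound 3 is within the usual scatter of this assay, so the two cannot be told apart; its gap to compound 2 lies beyond the scatter, so compound 2 is cleared more slowly than compound 1.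

Compound 4, `CN1C(=O)C2=C(C1=O)N(CC(=O)Nc1ccc(-c3ccccc3)cc1)CCC2`, is the next compound and has not been measured yet. It differs from compound 1 in one place: phenyl in place of pyridin-4-yl on an aromatic carbon. Within the data shown here, no pair of measured compounds shows this change, so no measured step guides the expectation. With nothing to suggest a large shift, compound 4 is expected to land near compound 1, with a small step of a 1.3-fold higher number from compound 1 to compound 4 (0.11 log units; within the scatter) that may well stay within the scatter. The estimate for compound 4 is 40 mL.min-1.g-1, in a range from 18 mL.min-1.g-1 to 85 mL.min-1.g-1.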

Compound 4, intrinsic clearance in microsomes: 22 mL.min-1.g-1
Compound 4: middle estimate off by 1.8-fold (0.26 log units), on the high side; the measured number falls inside the stated range.
By their numbers in this assay, from the lowest: compound 2; then compounds 4, 3 and 1 (each within the scatter of the next).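

In this assay, phenyl in place of pyridin-4-yl gives a 1.4-fold lower number from compound 1 to compound 4 (0.15 log units; within the scatter) and so the two compounds cannot be told apart. Among these compounds, this is the first direct reading of a single change at this place, an aromatic carbon para to a large group. Compounds 2 and 3 each differ from compound 1 in more than one place and could not isolate it. Here, the ring nitrogen of pyridin-4-yl, counted as its one hydrogen-bond acceptor, can be exchanged for carbon without a clear shift in the read-out, although no independent measurement shows what lies behind this result.

From the compounds shown here alone, whether a group of a different kind on this same carbon, such as an amine, a carboxylic acid or a morpholine ring, would also leave the read-out in this region remains open. Also open, going by these compounds, is whether the same exchange of pyridin-4-yl for phenyl would give a similarly small step on a different core, since this single pair speaks only for the core of compound 1.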